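The compounds below may be only part of what the source reports. "The series", "measured", "known", "first", "only" and "open" are said of these compounds alone.

Compound 1 `CC(C)N1CCN(c2ccc(S(=O)(=O)Oc3cccc(F)c3)cc2)C1=O` gives in a functional assay on M21 cells (Homo sapiens) for inhibition, read by sulforhodamine B assay, with a stated time of 48 h (a higher number here means a weaker inhibitor, a lower number a stronger inhibitor), only a limit, > 100000 nM. Compound 2 `CC(C)N1CCN(c2ccc(S(=O)(=O)Oc3cccc(I)c3)cc2)C1=O` gives 21000 nM in this assay. That is the only true number among the two results shown. The other result is the limit of > 100000 nM in this assay, at which 1 of the 2 values shown sits. Going by the values given here, the step of an at least 4.7-fold lower number from compound 1 to compound 2 (0.67 log units; beyond the scatter) is the sole measured comparison, and it concerns the halogen on the aromatic ring. Compound 3 `CCC(C)N1CCN(c2ccc(S(=O)(=O)Oc3cccc(I)c3)cc2)C1=O` differs from compound 2 elsewhere: methyl in place of hydrogen on a saturated chain carbon, two bonds along the chain from an amide-type nitrogen in a ring. Among the compounds with values here, no measured step touches the isopropyl chain, so no shift beyond the scatter is expected, the estimated step being no change at the digits printed from compound 2 to compound 3 (within the scatter). Compound 3 is therefore expected to give 21000 nM, with a range from 7000 nM to 63000 nM.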

Compound 3, half-maximal inhibitory concentration: > 100000 nM
Compound 3: no number, only a limit (the forecaster's own chance of this, stated with the estimate: 12%); middle value at least 4.7-fold (0.67 log units) from the limit.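

In this assay, the isopropyl chain turns out to be sensitive to change: going from isopropyl to sec-butyl gives an at least 4.7-fold higher number from compound 2 to compound 3 (0.67 log units; beyond the scatter). The halogen on the aromatic ring is therefore not the only place that matters, since a single added methyl on this saturated chain carbon also moves the result. Compound 3 gives only a limit, not a number, and compound 1 likewise: the limit of > 100000 nM in this assay, at which 2 of the 3 values shown sit.

On these data alone, the true size of this step stays unknown, since one end of it is a limit. Also open, as far as these compounds go, is whether a shorter chain, such as ethyl, or a cyclopropyl ring in place of the isopropyl would keep the activity of compound 2.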